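The compounds below may be only part of what the source reports. "The series", "measured", "known", "first", "only" and "open" are said of these compounds alone.

Within the data shown here, compound 2, with the structure `O=C1C(Nc2ccc(I)cc2)=CC(=O)c2ncncc21`, holds the higher of the two numbers so far in a functional assay on XF498 cells (Homo sapiens) for cytotoxicity, read by MTT assay, with a stated time of 72 h (on this read-out higher numbers stand for weaker inhibition and lower numbers for stronger inhibition), where compound 2 gives 0.04 ug/mL. Among the measured compounds shown here, its only neighbour is compound 1, the structure `O=C1C(Nc2ccccc2)=CC(=O)c2ncncc21`, which in this assay gives 0.01 ug/mL. For the measured compounds named here, the single measured step, a 4.0-fold higher number from compound 1 to compound 2 (0.60 log units; beyond the scatter), puts iodo in place of hydrogen on the aromatic carbon and raises the number modestly, beyond the scatter.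

Compound 3, the structure `Cc1ccc(NC2=CC(=O)c3ncncc3C2=O)cc1`, is reached from compound 2 by methyl in place of iodo on an aromatic carbon. Going by the values given here, no measured pair exchanges methyl for iodo, so the step from compound 1 to compound 2 is the only one that bears on the question: it shows that a substituent at this aromatic carbon weakened inhibition somewhat relative to the bare ring. Since methyl is a smaller group than iodo at the same place, compound 3 is expected to land between compound 1 and compound 2, with a step of a 2.0-fold lower number from compound 2 to compound 3 (0.30 log units; within the scatter) of modest size toward a lower number. Compound 3 is therefore estimated at 0.02 ug/mL, within a range from 0.007 ug/mL to 0.06 ug/mL.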

Compound 3, half-maximal inhibitory concentration: 0.13 ug/mL
Estimate against measurement, compound 3: 6.5-fold (0.81 log units) below; measured number outside the range, above it.
By their numbers in this assay, from the lowest: compound 1; then compound 2; then compound 3.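

In this assay, methyl on this aromatic carbon, para to a large group, gives a 13-fold higher number from compound 1 to compound 3 (1.11 log units; beyond the scatter), a large step where the iodo step was modest, so the ring with hydrogen here holds the lowest number of the three and both substituents raise it to different degrees. The exchange of iodo for methyl is itself a step beyond the scatter, a 3.3-fold higher number from compound 2 to compound 3 (0.51 log units; beyond the scatter), even though each group counts one heavy atom and neither brings a hydrogen-bond donor, an acceptor or a net charge, so at this place the outcome is not set by those counts alone. Nothing measured here accounts for methyl giving a higher number than iodo.

Still open, from the compounds shown here alone, is whether an amine, a hydroxyl group or a carboxylic acid on this aromatic carbon would stay close to compound 1 or raise the number as far as compound 3 does, and whether a longer chain such as ethyl would raise it further than methyl. Also open, going by these compounds, is whether the same order of hydrogen, iodo and methyl would hold on the other carbons of this ring.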